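The compounds below may be only part of what the source reports. "The series", "measured", "known", "first", "only" and "open" are said of these compounds alone.

Measured so far:
compound 1 `CC1=C(C(=O)OCC(C)C)C(c2ccco2)NC(=O)N1C` — 23%
compound 2 `CC1=C(C(=O)OCc2ccccc2)C(c2ccco2)NC(=O)N1C` — 11%

For the measured compounds named here, in an assay on membranes from HeLa cells for displacement of a labelled ligand from adenosine receptor A3 (Homo sapiens), read by scintillation counting, with a stated time of 180 min, tested at 1 uM (on this read-out higher numbers stand for more inhibition at the one concentration tested (going by the name of the read-out) and lower numbers for less inhibition), compound 1 gives 23%, the highest of the two numbers; the only measured step, a number 12 percentage points lower from compound 1 to compound 2 (beyond the scatter), concerns the ester side chain. Compound 3 `CC1=C(C(=O)OCC(C)C)C(c2ccsc2)NC(=O)N1C` differs from compound 1 by thiophen-3-yl in place of furan-2-yl on a saturated ring carbon. Going by the values given here, the measured step alters a different part of the shared core, so no step bears on this change, and nothing in the data points in either direction. The expected step is therefore a number 3 percentage points lower from compound 1 to compound 3 (within the scatter) in this assay, not beyond the scatter. Compound 3 is estimated at 20%, range 5% to 40%.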

Compound 3, a percentage reported as inhibition, at one concentration (the size of the read-out at that concentration, not a potency): 4%
Estimate against measurement, compound 3: 16 percentage points above; measured number below the stated range.
By their numbers in this assay, from the lowest: compounds 3 and 2 (each within the scatter of the next); then compound 1.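

In this assay, the substituent on the saturated ring carbon matters: swapping one five-membered aromatic ring for another with the same heavy-atom count is not silent here (a number 19 percentage points lower from compound 1 to compound 3 (beyond the scatter)). The earlier step concerned only the ester side chain, so this gives the only read on this position, and the size of the change is comparable to that of the ester step. No available measurement accounts for the loss. Still open, on these data alone, is whether it follows the sulfur or the ring attachment, which thiophen-2-yl and furan-3-yl would separate, and how phenyl would read at this position.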